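A few compounds are considered here, and "the series" means these few. Any claim that something is new, unique, unknown or untested is made for them only; others in the source may bear on it.

Measured compounds in this series:

compound 1 `CN1C/C(=C\c2ccccc2)C(=O)[C@]2(C1)[C@@H](c1ccccc1)CN(C)[C@@]21C(=O)Nc2ccccc21` — 73.3%
compound 2 `CN1C/C(=C\c2ccccc2)C(=O)[C@]2(C1)[C@@H](c1ccccc1)CN(C)[C@@]21C(=O)N(C)c2ccccc21` — 70.7%
compound 3 `CN1C/C(=C\c2ccc(Br)cc2)C(=O)[C@]2(C1)[C@@H](c1ccc(Br)cc1)CN(C)[C@@]21C(=O)Nc2ccccc21` — 69.3%

In a functional assay on the whole organism (strain Wister albino) for inhibition, with Rattus norvegicus as the target, read by paw edema, with stated times of 1 h and 2 h, at a dose of 50 mg/kg by the intraperitoneal route (on this read-out higher numbers stand for more inhibition at the one dose given (going by the name of the read-out) and lower numbers for less inhibition), compound 1 gives 73.3%, compound 2 gives 70.7% and compound 3 gives 69.3%. Compound 3 sits at the low end of the three numbers, but its gap to compound 2 and its gap to compound 1 both lie within the scatter, so compound 3 cannot be set apart from either of the other two on these data.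

The unmeasured compound 4 `CN1C/C(=C\c2ccc(Br)cc2)C(=O)[C@]2(C1)[C@@H](c1ccc(Br)cc1)CN(C)[C@@]21C(=O)N(C)c2ccccc21` differs from compound 3 in one place: methyl in place of hydrogen on an amide-type nitrogen in a ring. Among the measured compounds shown here, the one measured step that bears on this change is the same exchange on the bromine-free pair, a number 2.6 percentage points lower from compound 1 to compound 2 (within the scatter), which stayed within the scatter. Compound 3 and compound 4 carry the same two bromine substituents, and nothing measured suggests that these alter the outcome of the exchange. The expectation for this assay is therefore a step of a number 2.3 percentage points lower from compound 3 to compound 4 (within the scatter), that is, no change beyond the scatter. Compound 4 is expected to give 67% in this assay, with a range of 57% to 77%.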

Compound 4, a percentage reported as inhibition, in the whole organism at one dose (the size of the read-out at that dose, not a potency): 49.1%
Compound 4: middle estimate off by 17.9 percentage points, on the high side; measured number outside the range, below it.
By their numbers in this assay, from the lowest: compound 4; then compounds 3, 2 and 1 (each within the scatter of the next).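

In this assay, methyl in place of hydrogen on an amide-type nitrogen in a ring is not a neutral exchange on every core, since the step here is a number 20.2 percentage points lower from compound 3 to compound 4 (beyond the scatter). The outcome of the exchange at this position therefore differs between the bromine-free core and the core carrying the two bromine substituents: the same change on two cores in this assay, a number 2.6 percentage points lower (within the scatter) from compound 1 to compound 2 and a number 20.2 percentage points lower (beyond the scatter) from compound 3 to compound 4, 17.6 percentage points apart, beyond the scatter of two such steps. A reading of this nitrogen taken from the bromine-free pair alone does not carry over to the brominated pair, and among these four compounds the step beyond the scatter appears only where the methyl and the two bromine substituents occur together in compound 4.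

On these data alone, it remains open whether this drop is specific to methyl or would follow any group on this nitrogen, such as an ethyl, a longer chain or an acetyl. As far as these compounds go, it is also open whether both bromine substituents are needed for the drop, and a compound keeping only one of them, or carrying chlorine in their place, with and without the methyl, would bear on that.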